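The source may report more compounds than this note shows. Statements on the series, on what has been measured and on what is new or still open speak of the compounds shown alone.

Of the compounds shown here, three built on a shared core have been measured in an ADME assay on the whole organism (serum) with Homo sapiens as the target; a higher number here means that the compound lasts longer, a lower number that the compound disappears faster. Compound 1 `Cc1cn(C2CC(N=[N+]=[N-])C(COC(=O)CCCC(=O)OC(C)(C)C)O2)c(=O)[nH]c1=O` gives 0.55 h. Compound 3 `Cc1cn(C2CC(N=[N+]=[N-])C(COC(=O)OCCCO)O2)c(=O)[nH]c1=O` gives 0.167 h. Compound 2 `Cc1cn(C2CC(N=[N+]=[N-])C(COC(=O)NCCCC(=O)O)O2)c(=O)[nH]c1=O` yields no number but a limit of the assay, > 48 h. Its result sits at the limit of > 48 h in this assay, at which 1 of the 3 values shown sits. On the numbers shown, compound 2 therefore stands above the other two, since there is an at least 87-fold higher number from compound 1 to compound 2 (1.94 log units; beyond the scatter) and an at least 280-fold lower number from compound 2 to compound 3 (2.45 log units; beyond the scatter), while between the two compounds with numbers there is a 3.3-fold lower number from compound 1 to compound 3 (0.52 log units; beyond the scatter).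

Compound 4 `Cc1cn(C2CC(N=[N+]=[N-])C(COC(=O)OCCCCO)O2)c(=O)[nH]c1=O` has not yet been measured in this assay. It differs from compound 2 as follows: 4-hydroxybutoxy in place of (3-carboxypropyl)amino on a carbonyl carbon. For the measured compounds named here, the step that bears on this change is the one from compound 2 to compound 3, which carried 3-hydroxypropoxy in place of (3-carboxypropyl)amino on the same carbonyl carbon and was large; compound 4 carries 4-hydroxybutoxy at that place. A large fall in this assay is therefore expected for compound 4, with an at least 240-fold lower number from compound 2 to compound 4 (2.38 log units; beyond the scatter) as the expected step. Compound 4 is estimated to give about 0.2 h, within a range of 0.07 h to 0.6 h.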

Compound 4, half-life: 0.5 h
Compound 4: middle estimate off by 2.5-fold (0.40 log units), on the low side; low and high end bracket the measured number.
By their numbers in this assay, from the lowest: compound 3; then compounds 4 and 1 (each within the scatter of the next). At a limit, above all of these: compound 2.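

In this assay, 4-hydroxybutoxy on this carbonyl carbon also ends far from the (3-carboxypropyl)amino of compound 2, with an at least 96-fold lower number from compound 2 to compound 4 (1.98 log units; beyond the scatter), so the fall is not tied to 3-hydroxypropoxy alone. The chain length now matters as well: hydroxymethyl in place of hydroxy on the saturated chain carbon gives a 3.0-fold higher number from compound 3 to compound 4 (0.48 log units; beyond the scatter), while 4-hydroxybutoxy in place of 3-(tert-butoxycarbonyl)propyl gives a 1.1-fold lower number from compound 1 to compound 4 (0.04 log units; within the scatter), so those two compounds cannot be told apart. The result for compound 2 remains a limit of the assay and not a number: the limit of > 48 h in this assay, at which 1 of the 4 values shown sits.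

On these data alone, what stays open is which part of (3-carboxypropyl)amino goes with that result, the nitrogen on the carbonyl carbon or the carboxylic acid at the chain end. Also open, as far as these compounds go, are how a simple alkylamine or a hydroxyalkylamine on this carbonyl carbon would behave, and whether a longer chain would extend the half-life further.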